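Cytotoxicity of Quinoline Diamines: A Fluoro-to-Trifluoromethyl Step

The source may report more compounds than this note shows. Statements on the series, on what has been measured and on what is new or still open speak of the compounds shown alone.

The measured compounds are:
compound 1, `COc1ccc(Oc2ccc3c(NCCCNCc4cc(F)ccc4OC)ccnc3c2)cc1`, 7000 nM;
compound 2, `Fc1ccc(-c2ccc3c(NCCCNCc4ccco4)ccnc3c2)cc1`, 7760 nM;
compound 3, `COc1ccc(F)cc1CNCCCNc1ccnc2cc(Cc3ccc(F)cc3)ccc12`, 3530 nM.

All three were tested in an ADME assay on HepG2 cells (Homo sapiens) for cytotoxicity, read by luminescence, CellTiter-Glo and ATP content, with a stated time of 72 h; on this read-out higher numbers stand for an effect only at larger amounts of compound and lower numbers for an effect already at smaller amounts. On these numbers compound 2 stands highest; its nearest neighbour is compound 1, within the scatter, while compound 3 lies beyond it. Among the measured compounds shown here, the one measured step, a 2.0-fold lower number from compound 1 to compound 3 (0.30 log units; within the scatter), is within the scatter and concerns a different part of the shared core from the change followed here.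

Compound 4, `FC(F)(F)c1ccc(-c2ccc3c(NCCCNCc4ccco4)ccnc3c2)cc1`, has not yet been measured in this assay. It differs from compound 2 by trifluoromethyl in place of fluoro on an aromatic carbon, on an aromatic carbon of a six-membered aromatic ring of carbon only, para to a large group. For the measured compounds named here, no measured pair shows this exchange, so nothing among the three compounds bears directly on it. Going by the values given here, with only the step from compound 1 to compound 3 for guidance, which itself stayed within the scatter, no shift beyond the scatter is expected; the estimated step is a 1.1-fold lower number from compound 2 to compound 4 (0.04 log units; within the scatter).

Compound 4 is therefore expected to give about 7000 nM in this assay, estimated between 3000 nM and 16000 nM.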

Compound 4, half-maximal effective concentration: 3470 nM
For compound 4 the middle estimate is 2.0-fold (0.30 log units) above the measured one; the range from low to high includes it.
By their numbers in this assay, from the lowest: compounds 4, 3, 1 and 2 (each within the scatter of the next, the first and the last beyond it).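

In this assay, among the compounds shown here, trifluoromethyl in place of fluoro on an aromatic carbon, para to a large group, gives a 2.2-fold lower number from compound 2 to compound 4 (0.35 log units; beyond the scatter) and so provides the first step in this set to lie beyond the scatter, although a modest one. The position is therefore not indifferent to this exchange, in which fluoro, with 1 heavy atom, gives way to trifluoromethyl, with 4 heavy atoms, while neither group carries a hydrogen-bond donor or acceptor. Nothing available explains the shift, and no measurement bears on why this exchange moves the number in this direction.

From the compounds shown here alone, the result rests on a single pair, so it remains open whether other groups at this place, such as chloro, methyl, methoxy, a nitrile or a carboxylic acid, would move the number in the same way or whether the shift is particular to trifluoromethyl. For the compounds shown here, it is also open whether the same exchange would give a similar step on compounds with a different amine side chain, such as the one carried by compound 1 and compound 3.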